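Heteroaryl exchange on the acetamide chain carbon

The source may report more compounds than this note shows. Statements on the series, on what has been measured and on what is new or still open speak of the compounds shown alone.

The series shares one core bearing an acetamide whose chain carbon carries a small ring group. In a functional assay on CHO-K1 cells for antagonist activity at C-X-C chemokine receptor type 3 (Homo sapiens), read by FLIPR, with a stated time of 10 min, in the presence of a further agent that is not named here (on this read-out lower numbers stand for stronger inhibition and higher numbers for weaker inhibition), compound 1 `C[C@@H]1CN(c2sc(C(F)(F)F)nc2-c2nc3ccccc3[nH]2)CCN1C(=O)CN1C(=O)OC[C@@H]1c1ccccc1` gives 360 nM, and compound 2 `Cc1nc(C)n(CC(=O)N2CCN(c3sc(C(F)(F)F)nc3-c3nc4ccccc4[nH]3)C[C@H]2C)n1` gives 3.2 nM, the lowest of the two numbers shown. Among the compounds with values here, the one measured step, a 110-fold lower number from compound 1 to compound 2 (2.05 log units; beyond the scatter), shows that the group on the saturated chain carbon bound to the carbonyl carbon can move the read-out a long way. Compound 3 `C[C@@H]1CN(c2sc(C(F)(F)F)nc2-c2nc3ccccc3[nH]2)CCN1C(=O)Cn1cc(C2CCN(C)CC2)cn1` carries 4-(1-methylpiperidin-4-yl)-1H-pyrazol-1-yl in place of 3,5-dimethyl-1H-1,2,4-triazol-1-yl on a saturated chain carbon bound to a carbonyl carbon. Within the data shown here, no measured pair tests this exchange directly; the step from compound 1 to compound 2 bears on it only by showing that this position is sensitive, and it gives no direction for the present change. The expectation for compound 3 is therefore a number close to that of compound 2, with a modest rise allowed, a 2.5-fold higher number from compound 2 to compound 3 (0.40 log units; beyond the scatter). Compound 3 is estimated at 8 nM, within the range 1.5 nM to 50 nM.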

Compound 3, half-maximal inhibitory concentration: 15 nM
Beside the measured number, compound 3's estimate is 1.9-fold (0.27 log units) below it, within the range that was stated.
By their numbers in this assay, from the lowest: compound 2; then compound 3; then compound 1.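

In this assay, 4-(1-methylpiperidin-4-yl)-1H-pyrazol-1-yl in place of 3,5-dimethyl-1H-1,2,4-triazol-1-yl gives a 4.7-fold higher number from compound 2 to compound 3 (0.67 log units; beyond the scatter), a modest step, so the saturated chain carbon bound to a carbonyl carbon holds a group of 12 heavy atoms rather than 7, with an added non-aromatic ring, at a limited cost. The same group gives a 24-fold lower number from compound 1 to compound 3 (1.38 log units; beyond the scatter), so both five-membered aromatic ring groups lie far lower than 2-oxo-4-phenyl-1,3-oxazolidin-3-yl. No measurement shown accounts for either step.

Going by these compounds, whether the rise belongs to the change of aromatic ring or to the 1-methylpiperidin-4-yl group remains open, as the two change together here. An unsubstituted 1H-pyrazol-1-yl group, or a pyrazole carrying a carboxylic acid instead of the 1-methylpiperidin-4-yl group, would separate these two parts.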